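Plasma stability notes: capping the carboxy of compound 1

This account rests on a few compounds, and the source may have more. Where it says the series, first, only, none or still open, it means among the compounds named here.

Measured so far in an ADME assay on a cell-free system (plasma, Homo sapiens) for metabolic stability, read by LC-MS; on this read-out lower numbers stand for a shorter-lived compound and higher numbers for a longer-lived compound:
- compound 1, `NCc1ccc(C(=O)Nc2ccncc2F)cc1-c1cccc(C(=O)O)c1`: > 2 h
- compound 2, `CCCCCCOC(=O)c1cccc(-c2cc(C(=O)Nc3ccncc3)ccc2CN)c1`: 0.833 h
- compound 3, `CCOC(=O)c1cccc(-c2cc(C(=O)Nc3ccncc3)ccc2CN)c1`: 0.683 h

Compound 1 sits at the limit of > 2 h in this assay, at which 1 of the 3 values shown sits, so for it only a limit and no number is known. For the measured compounds named here, compounds 2 and 3 both carry a chain on the oxygen next to the carbonyl group and both give short half-lives in this assay; the one computed step, a 1.2-fold lower number from compound 2 to compound 3 (0.09 log units; within the scatter), shows that swapping one such chain for another changes little. Going by the values given here, no step is computed between compound 1 and either of these, since they differ in more than one place; their values show only that the free carboxy of compound 1 outlasts the assay window while compounds 2 and 3 do not.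

Compound 4, `NCc1ccc(C(=O)Nc2ccncc2F)cc1-c1cccc(C(=O)OCC2CCCC2)c1`, has not been measured. It differs from compound 1 by cyclopentylmethyl in place of hydrogen on an oxygen next to a carbonyl group. That change puts compound 4 on the same footing as compounds 2 and 3, whose values are the nearest guide. Compound 4 is therefore expected to give 0.8 h, within 0.4 h to 1.6 h. The expected step, an at least 2.5-fold lower number from compound 1 to compound 4 (0.39 log units; beyond the scatter), is a move off the limit toward the short-lived end, though the true size is uncertain because compound 1 shows only > 2 h.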

Compound 4, half-life: 0.283 h
The estimate for compound 4 lay 2.8-fold (0.45 log units) above the measured number; the whole stated range lies above it.
By their numbers in this assay, from the lowest: compound 4; then compounds 3 and 2 (each within the scatter of the next). At a limit, above all of these: compound 1.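

On the core of compound 1, capping the carboxy now has a direct reading in this assay: an at least 7.0-fold lower number from compound 1 to compound 4 (0.84 log units; beyond the scatter). The earlier compounds shown here offered only a swap of one chain for another on the oxygen next to a carbonyl group, a 1.2-fold lower number from compound 2 to compound 3 (0.09 log units; within the scatter), and so said nothing about hydrogen against a chain at this place; the new pair shows that on this core, cyclopentylmethyl in place of hydrogen on that oxygen takes the half-life from the limit down to a measured number, by a step beyond the scatter. The size of that step is a floor and not a measured gap, as the value for compound 1 is a limit: the limit of > 2 h in this assay, at which 1 of the 4 values shown sits.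

Steps from compound 4 to compound 2 or compound 3 cannot be read, since those pairs differ in more than one place, so the part played by the cyclopentylmethyl group itself, as against an ethyl or hexyl chain on the same core, stays open. Also open, on these data alone, are whether an amide made from a simple amine, or a branched chain on that oxygen, would behave like compound 4, and whether compound 4 yields compound 1 in this assay.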